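A few compounds are considered here, and "the series" means these few. Any claim that something is new, unique, unknown or untested is made for them only; others in the source may bear on it.

Measured compounds, with their values in an ADME assay on BJ cells (Homo sapiens) for cytotoxicity, with a stated time of 72 h; on this read-out lower numbers stand for an effect already at smaller amounts and higher numbers for an effect only at larger amounts of compound:

compound 1 `COc1ccc(-c2nc3c(c(C)nn3-c3ccccc3)c(-c3ccccc3O)c2C#N)cc1`: > 23000 nM, a limit of the assay and not a number
compound 2 `CCc1ccc(-c2nc3c(c(C)nn3-c3ccccc3)c(-c3ccccc3Br)c2C#N)cc1`: > 20000 nM, a limit of the assay
compound 3 `CCc1ccc(-c2nc3c(c(C)nn3-c3ccccc3)c(-c3ccccc3OC(F)(F)F)c2C#N)cc1`: > 20000 nM, a limit of the assay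

Compound 1 therefore has no number of its own in this assay, only the limit (the limit of > 23000 nM in this assay, at which 1 of the 3 values shown sits). The other two values sit at the limit (the limit of > 20000 nM in this assay, at which 2 of the 3 values shown sit), so nothing in the series is resolved. Among the measured compounds shown here, the one single-point step, a step that the two limits leave unreadable from compound 2 to compound 3, stays unreadable because both of its ends are limits.

Compound 4 `Cc1nn(-c2ccccc2)c2nc(-c3ccc(F)cc3)c(C#N)c(-c3ccccc3O)c12` differs from compound 1 by fluoro in place of methoxy on an aromatic carbon. For the measured compounds named here, no measured step involves this change, and the only measured step gives no size or direction, so no step beyond the scatter is expected in this assay in either direction. Since compounds 1, 2 and 3 all sit at limits, compound 4 is expected to do the same.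

Compound 4 is estimated at 25000 nM, within 10000 nM to 60000 nM. The expected step that the limit leaves unreadable from compound 1 to compound 4 is accordingly none beyond the scatter.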

Compound 4, half-maximal effective concentration: > 20000 nM
Compound 4 was reported as a limit (the forecaster's own chance of this, stated with the estimate: 85%); the middle value lies beyond the limit too.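

In this assay compound 1 gives > 23000 nM, a limit of the assay. Compound 4 gives > 20000 nM, also a limit, so the 4-methoxyphenyl to 4-fluorophenyl change from compound 1 to compound 4 yields no readable step. The compounds shown leave open at what concentration any of them reaches a half-maximal effect in this assay.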